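The compounds below may be only part of what the source reports. "The series", "measured", "known", "first", "only" and "open" are said of these compounds alone.

Three compounds built on a shared core were tested in a functional assay on KB cells (Homo sapiens) for antiproliferative activity, read by MTT assay, with a stated time of 72 h; on this read-out lower numbers stand for stronger inhibition and higher numbers for weaker inhibition. Compound 1 `CN(C(=O)c1ccccc1)c1ccc2[nH]c(-c3n[nH]c4ccccc34)cc2n1` gives 8580 nM, compound 2 `CN(C(=O)CCc1ccccc1)c1ccc2[nH]c(-c3n[nH]c4ccccc34)cc2n1` gives 7380 nM, and compound 3 `CN(c1ccc2[nH]c(-c3n[nH]c4ccccc34)cc2n1)S(=O)(=O)c1ccc(Cl)cc1` gives 8350 nM. Compound 3 stands close to both of the others: a 1.0-fold lower number from compound 1 to compound 3 (0.01 log units; within the scatter) and a 1.1-fold higher number from compound 2 to compound 3 (0.05 log units; within the scatter), and likewise a 1.2-fold lower number from compound 1 to compound 2 (0.07 log units; within the scatter). Compound 4 `CN(C(=O)Nc1ccccc1)c1ccc2[nH]c(-c3n[nH]c4ccccc34)cc2n1` carries phenylcarbamoyl in place of (4-chlorophenyl)sulfonyl on a nitrogen on an aromatic ring. All three measured steps swap the group on that same nitrogen, and none of them moved the read-out beyond the scatter, so no step beyond the scatter is expected in this assay for this swap either. Compound 4 is therefore expected to give about 8000 nM, with a range from 4000 nM to 16000 nM. The expected step is a 1.0-fold lower number from compound 3 to compound 4 (0.02 log units; within the scatter).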

Compound 4, half-maximal inhibitory concentration: 32 nM
Estimate against measurement, compound 4: 250-fold (2.40 log units) above; measured number outside the range, below it.
By their numbers in this assay, from the lowest: compound 4; then compounds 2, 3 and 1 (each within the scatter of the next).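

The nitrogen on an aromatic ring is not indifferent to its group in this assay: phenylcarbamoyl brings a 260-fold lower number from compound 3 to compound 4 (2.42 log units; beyond the scatter), along with a 230-fold lower number from compound 2 to compound 4 (2.36 log units; beyond the scatter) and a 270-fold lower number from compound 1 to compound 4 (2.43 log units; beyond the scatter). Among these compounds, the flat results among the earlier compounds therefore held only for the groups they carry, and anilino on the carbonyl carbon stands apart from phenyl and phenethyl. No measurement at hand explains this jump. Going by these compounds, whether methylcarbamoyl, or a carboxylic acid on the phenyl ring of phenylcarbamoyl, would keep the low number remains open.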